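A few compounds are considered here, and "the series" means these few. Any claim that something is new, unique, unknown or untested is made for them only; others in the source may bear on it.

Measured compounds:
compound 1 `O=C(CCc1ccccc1)NCc1ccc2[nH]c(=O)c(-c3nccs3)c(CCc3ccccc3)c2c1` gives 3250 nM
compound 2 `CC(C)(NC(=O)COc1ccc2[nH]c(=O)c(-c3ccccn3)c(CCc3ccccc3)c2c1)c1ccccc1` gives 1370 nM
compound 3 `O=C(COc1ccc2[nH]c(=O)c(-c3nccs3)c(CCc3ccccc3)c2c1)NC1(c2ccccc2)CC1` gives 13 nM

In an assay on CHO-K1 cells for displacement of a labelled ligand from adenosine receptor A1 (Homo sapiens), with a stated time of 2 h (on this read-out lower numbers stand for stronger inhibition and higher numbers for weaker inhibition), compound 1 stands at the highest number of the three. Compound 2 sits nearer, at a gap beyond the scatter, while compound 3 lies furthest away, far beyond the scatter. Compound 4 `CC(C)(NC(=O)NCc1ccc2[nH]c(=O)c(-c3nccs3)c(CCc3ccccc3)c2c1)c1ccccc1` has not yet been measured. It differs from compound 1 in one place: (1-methyl-1-phenylethyl)amino in place of phenethyl on a carbonyl carbon. Compound 3, with the same thiazole and a branched amide group, gives 13 nM, and compound 2, carrying the (1-methyl-1-phenylethyl) group, gives 1370 nM; both reach lower numbers than compound 1. A step downward in this assay, beyond the scatter, is therefore expected from compound 1 to compound 4, a 3.3-fold lower number from compound 1 to compound 4 (0.51 log units; beyond the scatter). Compound 4 is estimated at 1000 nM, within 250 nM to 4000 nM.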

Compound 4, inhibition constant: 68 nM
Compound 4: middle estimate off by 15-fold (1.17 log units), on the high side; the whole stated range lies above it.
By their numbers in this assay, from the lowest: compound 3; then compound 4; then compound 2; then compound 1.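

In this assay, within the data shown here, the swap of one group on a carbonyl carbon gives a 48-fold lower number from compound 1 to compound 4 (1.68 log units; beyond the scatter), the first step here that changes a single place. It shows that this place alone, with the thiazole and the shared core unchanged, can carry a large change in the number. Nothing available explains this step. The swap brings in a nitrogen and a branched carbon together, and the compounds shown do not separate the two. Phenethylamino on the same carbonyl carbon would separate them, and its effect remains open.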